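Sulfur Configuration and Cytotoxicity in a Nitroimidazole Pair

The source may report more compounds than this note shows. Statements on the series, on what has been measured and on what is new or still open speak of the compounds shown alone.

Compound 1 `O=[N+]([O-])c1cn2c(n1)[S+]([O-])CC(OCc1ccc(-c3ccc(OC(F)(F)F)cc3)cn1)C2` gives 16000 nM; 54000 nM (2 entries) in an ADME assay on MRC5 cells (Homo sapiens) for cytotoxicity; on this read-out lower numbers stand for stronger inhibition and higher numbers for weaker inhibition. Compound 2 `O=[N+]([O-])c1cn2c(n1)[S@@+]([O-])C[C@@H](OCc1ccc(OC(F)(F)F)cc1)C2` reaches only the limit > 64000 nM in this assay, a ceiling of the measurement rather than a number, so compound 2 stands at the weak end of what the two measured compounds show. Compound 3 `O=[N+]([O-])c1cn2c(n1)[S@+]([O-])C[C@@H](OCc1ccc(OC(F)(F)F)cc1)C2` differs from compound 2 in this way: the two compounds have the same atoms and bonds and differ only in configuration as drawn: 1 of 2 stereo elements differ; a stereocentre at a sulfur is drawn S in compound 2 and R in compound 3. Among the compounds with values here, no measured pair shows the effect of such a change, so the expected shift is a number no higher from compound 2 to compound 3 (the limit leaves the size open) in this assay, none beyond the scatter. Compound 3 is expected to give 64000 nM in this assay, within 25000 nM to 130000 nM.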

Compound 3, half-maximal inhibitory concentration: 50000 nM
Compound 3: the middle estimate sits 1.3-fold (0.11 log units) above what was measured; the measured number falls inside the stated range.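

In this assay, the only pair shown that isolates the sulfur stereocentre gives an at least 1.2-fold lower number from compound 2 to compound 3 (0.10 log units; that floor lies within the scatter). The value of compound 2 is a limit, > 64000 nM. The step therefore fixes only a floor, so this pair shows no effect of the sulfur configuration beyond the scatter, yet it cannot exclude a larger one.

The compounds shown leave open whether the same change at sulfur would matter with the longer side chain of compound 1. They also leave open what a compound carrying an amine or a carboxylic acid would give in this assay.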